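The compounds below may be only part of what the source reports. "The series", "measured", "known", "first", "only" and "open" are said of these compounds alone.

Measured compounds:
- compound 1, `CCOC(=O)c1cnn(-c2nc(-c3cccc(OC)c3OC)c(C#N)c(=O)n2C)c1N`: 67 ug/mL
- compound 2, `CSc1nc(-c2cccs2)c(C#N)c(=O)n1C`: 72 ug/mL

Both numbers come from a functional assay, with a stated time of 10 min; on this read-out lower numbers stand for stronger inhibition and higher numbers for weaker inhibition. Compound 1 has the lower of the two values, but the gap to compound 2 lies within the scatter of this assay, so the two are not separated by the data as they stand; neither can be called the more potent one. Among the measured compounds shown here, the two measured compounds differ in several places at once, so no single structural step between them has been followed, and no step size is known for any single change.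

Compound 3, `CCOC(=O)c1cnn(-c2nc(-c3cccc(O)c3O)c(C#N)c(=O)n2C)c1N`, is the unmeasured analogue of compound 1. The change is 2,3-dihydroxyphenyl in place of 2,3-dimethoxyphenyl on an aromatic carbon. Nothing in the measured pair speaks to this kind of change, so there is no basis for expecting a step beyond the scatter in either direction. The step from compound 1 to compound 3 in this assay is estimated at a 1.1-fold lower number from compound 1 to compound 3 (0.05 log units; within the scatter), that is, none beyond the usual spread. Compound 3 is accordingly expected at about 60 ug/mL, with a range from 25 ug/mL to 150 ug/mL.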

Compound 3, half-maximal inhibitory concentration: 53 ug/mL
The estimate for compound 3 lay 1.1-fold (0.05 log units) above the measured number; measured number inside the range.
By their numbers in this assay, from the lowest: compounds 3, 1 and 2 (each within the scatter of the next).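

In this assay, the series now has its first single-place step, on an aromatic carbon of a six-membered aromatic ring with 2 nitrogen: 2,3-dihydroxyphenyl in place of 2,3-dimethoxyphenyl gives a 1.3-fold lower number from compound 1 to compound 3 (0.10 log units; within the scatter). The entering group carries hydrogen-bond donors and the leaving group carries none, and it also has fewer heavy atoms, yet this read-out does not separate compound 1 from compound 3, so the two oxygen substituents are interchangeable here as far as this one pair shows. No measured property bears on this result, so nothing can be said about what lies behind the size of the step.

Still open, going by these compounds, is whether an amine or a carboxylic acid on the phenyl ring, or a longer chain such as ethoxy on the oxygen atoms, would give a step beyond the scatter at this position. The compounds shown also hold no single-place step elsewhere on compound 1, so the response of the rest of the molecule remains unknown.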